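Series notes: from compound 3 to compound 4

The source may report more compounds than this note shows. Statements on the series, on what has been measured and on what is new or still open speak of the compounds shown alone.

For the measured compounds named here, compound 3 `C[C@@H](c1ccc(Cl)cc1)N1Cc2cncn2C(C[C@@H](O)c2ccccc2)S1(=O)=O` gives 2.4 nM in an assay on cells for inhibition of cytochrome P450 11B2, mitochondrial (Homo sapiens) (a lower number here means a stronger inhibitor, a higher number a weaker inhibitor), the lowest of the two numbers so far. Compound 1 `C[C@@H](c1ccc(Cl)cc1)N1Cc2cncn2C(CC2(C)COC2)S1(=O)=O` stands nearest, in this assay at 7.8 nM, separated by a 3.3-fold lower number from compound 1 to compound 3 (0.51 log units; beyond the scatter). Compound 2 `CC(C)CC1n2cncc2CN(C2CC2)S1(=O)=O` reaches only a limit of this assay, > 1000 nM, which is a limit and not a number (the limit of > 1000 nM in this assay, at which 1 of the 3 values shown sits). Compound 4 `CC(C)OCC1n2cncc2CN([C@@H](C)c2ccc(Cl)cc2)S1(=O)=O` differs from compound 3 by isopropoxy in place of hydroxy(phenyl)methyl on a saturated chain carbon bound to a saturated ring carbon. Going by the values given here, the only measured step bearing on this change is a 3.3-fold lower number from compound 1 to compound 3 (0.51 log units; beyond the scatter); compound 4 gives up the group that gained there and carries a smaller group, as compound 1 does, so a modest rise in number is expected, of the size a 5.0-fold higher number from compound 3 to compound 4 (0.70 log units; beyond the scatter). Compound 4 is therefore estimated at 12 nM, in the range 4 nM to 40 nM.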

Compound 4, half-maximal inhibitory concentration: 0.8 nM
The estimate for compound 4 lay 15-fold (1.18 log units) above the measured number; the measured number lies below the stated range.
By their numbers in this assay, from the lowest: compound 4; then compound 3; then compound 1. At a limit, above all of these: compound 2.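

In this assay, a group with no ring and no hydrogen-bond donor serves at this place, on a saturated chain carbon bound to a saturated ring carbon: swapping hydroxy(phenyl)methyl for isopropoxy gives a 3.0-fold lower number from compound 3 to compound 4 (0.48 log units; beyond the scatter). Isopropoxy also outdoes 3-methyloxetan-3-yl, with a 9.8-fold lower number from compound 1 to compound 4 (0.99 log units; beyond the scatter). Nothing measured here gives a cause for either step.

The compounds shown leave open whether the oxygen of isopropoxy matters at all. As far as these compounds go, how a longer ether such as butoxy, or an amine in its place, would read at this position also stays open.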